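Swapping an aromatic amide cap for a cyclobutylmethyl group

The compounds below may be only part of what the source reports. "The series", "measured", "known", "first", "only" and "open" are said of these compounds alone.

Of the compounds shown here, three have been measured so far. Compound 1 `C[C@@H]1C[C@H](c2nc(-c3ccc4ccccc4n3)no2)CCN1C(=O)Nc1ccccc1Cl` gives 2400 nM in a functional assay on Shh Light II cells (Mus musculus) for inhibition, read by a luciferase reporter; on this read-out lower numbers stand for stronger inhibition and higher numbers for weaker inhibition. Compound 2 `Cc1noc(C)c1NC(=O)N1CCC(c2nc(-c3ccc4ccccc4n3)no2)CC1` gives 3000 nM in this assay, the highest number of the three, and its number and that of compound 1 lie within the scatter of each other. Compound 3 `Cn1c(-c2noc(C3CCN(C(=O)NC4CCS(=O)(=O)CC4)CC3)n2)nc2ccccc21` gives 350 nM in this assay, a number beyond the scatter from compound 2, though compound 3 differs from compound 2 in more than one place, so no single step can be read from that gap.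

Compound 4 `O=C(NCC1CCC1)N1CCC(c2nc(-c3ccc4ccccc4n3)no2)CC1` has not yet been measured. It differs from compound 2 in a single place: cyclobutylmethyl in place of 3,5-dimethyl-1,2-oxazol-4-yl on an amide-type nitrogen. For the measured compounds named here, no measured pair shows this change on its own. A step of modest size toward a lower number is expected, though a result within the scatter of compound 2 would not be surprising. For compound 4 the expected result in this assay is 1500 nM, within a range from 400 nM to 5000 nM. This estimate means a step of a 2.0-fold lower number from compound 2 to compound 4 (0.30 log units; within the scatter).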

Compound 4, half-maximal inhibitory concentration: 410 nM
Compound 4: middle estimate off by 3.7-fold (0.56 log units), on the high side, and the stated range covers the measured number.
By their numbers in this assay, from the lowest: compounds 3 and 4 (each within the scatter of the next); then compounds 1 and 2 (each within the scatter of the next).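

On this amide-type nitrogen, the aromatic 3,5-dimethyl-1,2-oxazol-4-yl group is not required for inhibition in this assay: replacing it with cyclobutylmethyl, a non-aromatic group of carbon only, gives a 7.3-fold lower number from compound 2 to compound 4 (0.86 log units; beyond the scatter) on an otherwise unchanged structure. For the compounds shown here, this is the first step here that can be read on its own, and it shows that changing this one group can shift the number beyond the scatter. No measurement at hand explains the size of this step.

Going by these compounds alone, with only this pair, the effect of losing the aromatic ring cannot be separated from that of the ring size or the added carbon link. Going by these compounds, how a cyclobutyl group, a cyclopentylmethyl group or an open butyl chain would compare on the same nitrogen remains open.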